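This account rests on a few compounds, and the source may have more. Where it says the series, first, only, none or still open, it means among the compounds named here.

Compound 1, `CCOC(=O)c1ccc(-c2nn(-c3ccoc3)c3ccccc23)cc1`: in a functional assay on cells (Platelet, Homo sapiens) for inhibition (on this read-out higher numbers stand for weaker inhibition and lower numbers for stronger inhibition), compound 1 gives > 10000 nM, which is a limit of the assay and not a number.
Compound 2, `O=C(O)c1ccc(-c2nn(Cc3ccccc3)c3ccccc23)cc1`: in this assay compound 2 gives > 10000 nM, again a limit of the assay rather than a number.

Compound 2 therefore stands at the edge of what this assay reports, and it does not stand alone there, because of the limit of > 10000 nM in this assay, at which 2 of the 2 values shown sit. Among the compounds with values here, no step between two measured compounds with a numerical result is available, so there is nothing to gauge the size of a change against.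

The unmeasured compound 3, `OCc1ccc(-c2nn(Cc3ccccc3)c3ccccc23)cc1`, differs from compound 2 in one place: hydroxymethyl in place of carboxy on an aromatic carbon. With both measured values sitting at the limit, the expected step from compound 2 to compound 3 in this assay is a step that the limit leaves unreadable from compound 2 to compound 3, that is, no change beyond the usual scatter, and the most likely outcome is that compound 3 also returns only a limit. Compound 3 is expected to give about 20000 nM in this assay, within a range of 5000 nM to 80000 nM.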

Compound 3, half-maximal inhibitory concentration: > 10000 nM
Compound 3: a limit, no number; the forecaster's own chance of this, stated with the estimate: 75%; the middle value lies beyond the limit too.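

In this assay compound 3 gives > 10000 nM, which is a limit of the assay and not a number. Compound 2 also stands at a limit, so no step can be read from compound 2 to compound 3. The compounds shown leave open what any change to them would need to give a number in this assay: the limit of > 10000 nM in this assay, at which 3 of the 3 values shown sit.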